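One Aryl Swap Carried Across Two Cores

The source may report more compounds than this note shows. Statements on the series, on what has been measured and on what is new or still open speak of the compounds shown alone.

Measured so far:
compound 1, `CC1CCN(c2c(S(=O)(=O)c3cc(Cl)cc(Cl)c3)cnc3ccc(Cl)cc23)CC1`: 88%
compound 2, `CC1CCN(c2c(S(=O)(=O)c3ccc(F)cc3)cnc3ccc(Cl)cc23)CC1`: 89%
compound 3, `CC1CCN(c2c(S(=O)(=O)c3cc(Cl)cc(Cl)c3)cnc3cc(F)ccc23)CC1`: 87%

The three measured compounds were tested in an assay on isolated protein for displacement of a labelled ligand from metabotropic glutamate receptor 5 (Homo sapiens), with a stated time of 60 min, tested at 1 uM; on this read-out lower numbers stand for less inhibition and higher numbers for more inhibition at the one concentration tested (going by the name of the read-out). Compound 1 gives 88% there, and compound 2 gives 89%. Between them stands one change, (4-fluorophenyl in place of 3,5-dichlorophenyl on a sulfonyl sulfur), and the step it made was a number 1 percentage points higher from compound 1 to compound 2 (within the scatter). Compound 3 carries a different core; the difference between the core of compound 3 and the core of compound 1 is not broken down here. In this assay compound 3 gives 87%, a number that sits with the other two inside the usual scatter, so no order among the three can be read from these figures.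

Compound 4, `CC1CCN(c2c(S(=O)(=O)c3ccc(F)cc3)cnc3cc(F)ccc23)CC1`, has not yet been measured. Going by the values given here, it is related to compound 3 by 4-fluorophenyl in place of 3,5-dichlorophenyl on a sulfonyl sulfur, and this is the same change as the one from compound 1 to compound 2, made on the same kind of sulfonyl sulfur. That change occurs twice among these four compounds. Since the change left the read-out essentially flat in a number 1 percentage points higher from compound 1 to compound 2 (within the scatter), the step is expected to be of the same flat size, a number 1 percentage points higher from compound 3 to compound 4 (within the scatter), resting on that single earlier instance. Compound 4 is therefore estimated to give about 88% in this assay, with an expected range from 80% to 95%.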

Compound 4, a percentage reported as inhibition, at one concentration (the size of the read-out at that concentration, not a potency): 74.5%
Compound 4: middle estimate off by 13.5 percentage points, on the high side; the whole stated range lies above it.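

On the core of compound 3, putting 4-fluorophenyl in place of 3,5-dichlorophenyl on the sulfonyl sulfur gave, in this assay, a number 12.5 percentage points lower from compound 3 to compound 4 (beyond the scatter), and set beside the earlier instance of the same change, the two steps compare as follows: the same change on two cores in this assay, a number 1 percentage points higher (within the scatter) from compound 1 to compound 2 and a number 12.5 percentage points lower (beyond the scatter) from compound 3 to compound 4, 13.5 percentage points apart, within the scatter of two such steps

Taken alone, the second step clears the usual scatter and the first does not, but the pair gives no firm ground for saying that the core alters what this change does. Nor does it show that the change carries unaltered from one core to the other, since there are only two instances, each built from readings at one concentration, and they leave the size of the step on any further core uncertain.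

The compounds shown leave open whether an aryl group bearing a methoxy group or a nitrile on the sulfonyl sulfur would give similar steps on these two cores. They also leave open whether the same swap would stay flat or fall on a third core, which could help show whether the lower number for compound 4 74.5% reflects a real dependence on the core.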